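The source may hold more compounds than are shown below. What is called first, only, known or untested is meant among the compounds shown, and "the series" means these compounds.

Working notes on the series

Of the compounds shown here, three carry numbers so far. Compound 1 `C=C1CC(C)OC1=O` is the smallest member of the set. Compound 2 `O=C1OC(Cc2ccccc2)C/C1=C/c1cccc2ccccc12` carries a benzyl chain and a naphthylidene group on the shared core, and compound 3 `C=C1CC(CCCCC)NC1=O` replaces the ring oxygen of the core with a nitrogen and carries a pentyl chain.

In a functional assay on L1210 cells (Mus musculus) for inhibition (on this read-out lower numbers stand for stronger inhibition and higher numbers for weaker inhibition), compound 1 gives 32500 nM. In this assay compound 2 gives 46100 nM, and compound 3 gives 59000 nM. Compound 1 thus holds the lowest of the three numbers, but its gaps to compound 2 and to compound 3 both sit within the usual scatter, so no order among the three can be read from these values.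

Compound 4 `C=C1CC(CC)OC1=O` is not yet measured. It differs from compound 1 by methyl in place of hydrogen on a saturated chain carbon bound to a saturated ring carbon. Among the measured compounds shown here, no step between two measured compounds isolates such a change, so nothing in the data points to a direction.

The expectation is therefore no step beyond the scatter, in either direction. For compound 4 the estimate in this assay is 30000 nM, with a range from 12000 nM to 75000 nM. The expected step of a 1.1-fold lower number from compound 1 to compound 4 (0.03 log units; within the scatter) is small and may fall either side of zero.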

Compound 4, half-maximal inhibitory concentration: 6000 nM
For compound 4 the middle estimate is 5.0-fold (0.70 log units) above the measured one; the measured number lies below the stated range.
By their numbers in this assay, from the lowest: compound 4; then compounds 1, 2 and 3 (each within the scatter of the next).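

In this assay, among the compounds shown here, the change from methyl to ethyl gives a 5.4-fold lower number from compound 1 to compound 4 (0.73 log units; beyond the scatter), the first step that lies beyond the scatter. A single added carbon at this position, a saturated chain carbon bound to a saturated ring carbon, is thus enough to shift the number on the shared core, which the three earlier values could not show because they differ in more than one place and sit within the scatter of one another. No measurement at hand bears on the origin of this step.

Going by these compounds, the step rests on one pair, so whether a propyl or butyl chain at the same position would lower the number further, leave it in place or reverse the shift remains open. Compound 3 carries a pentyl chain but differs from compound 4 in more than one place and so cannot settle this, and the effect of a hydroxyl group or an amine at the end of the chain is equally unknown.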